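The source may report more compounds than this note shows. Statements on the series, on what has been measured and on what is new or still open speak of the compounds shown alone.

The measured compounds:

Compound 1, `CS/C(=N\C(=O)c1ccno1)NC(=O)c1ccno1`. In a functional assay on HepG2 cells (Homo sapiens) for cytotoxicity, read by MTT assay, with a stated time of 72 h (a higher number here means a weaker inhibitor of growth, a lower number a stronger inhibitor of growth), compound 1 gives > 100000 nM, which is a limit of the assay and not a number.

Compound 2, `O=C(/N=C(/NC(=O)c1ccno1)[Se]Cc1ccccc1)c1ccno1`. In this assay compound 2 gives 58900 nM.

Compound 3, `O=C(/N=C(/NC(=O)c1cccs1)[Se]Cc1ccccc1)c1cccs1`. In this assay compound 3 gives 58100 nM.

Compound 2 and compound 3 share the same arrangement around the carbon with a double bond to nitrogen, but their cores differ elsewhere, and the difference between the two cores is not broken down here. Their numbers in this assay lie within the usual scatter of each other.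

One change has already been measured once. Going from compound 2 to compound 1, the structures differ as follows: a group of 2 heavy atoms (1 carbon, 1 sulfur; no ring) in place of a group of 8 heavy atoms (7 carbon, 1 selenium; one six-membered aromatic ring of carbon only), on a carbon with a double bond to nitrogen. That step gave an at least 1.6-fold higher number from compound 2 to compound 1 (0.22 log units; that floor lies within the scatter). The size of the step can only be given as a floor, because the value of compound 1 sits at the limit of > 100000 nM in this assay, at which 1 of the 3 values shown sits.

Compound 4, `CS/C(=N\C(=O)c1cccs1)NC(=O)c1cccs1`, has not yet been measured. It differs from compound 3 in this way: a group of 2 heavy atoms (1 carbon, 1 sulfur; no ring) in place of a group of 8 heavy atoms (7 carbon, 1 selenium; one six-membered aromatic ring of carbon only), on a carbon with a double bond to nitrogen. For the measured compounds named here, this is the same change as the one from compound 2 to compound 1, made on the core of compound 3.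

If the change acts on the core of compound 3 as it did on the core of compound 2, the expected step is a 2.1-fold higher number from compound 3 to compound 4 (0.32 log units; beyond the scatter), resting on the step measured from compound 2 to compound 1 in this assay. For compound 4 the estimated value in this assay is 120000 nM, expected to fall between 55000 nM and 300000 nM, with a fair chance that the assay again reports only a limit.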

Compound 4, concentration for total growth inhibition: > 100000 nM
Compound 4: no number, only a limit; the forecaster's own chance of this, stated with the estimate: 65%; the middle value does not contradict the limit.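

In this assay compound 4 gives > 100000 nM, which is a limit of the assay and not a number. Putting methylsulfanyl in place of the group of 8 heavy atoms that holds selenium, on the carbon with a double bond to nitrogen, can therefore be read only as a floor, an at least 1.7-fold higher number from compound 3 to compound 4 (0.23 log units; that floor lies within the scatter), and the two cores can be set side by side only as floors: the same change on two cores in this assay, an at least 1.6-fold higher number (0.22 log units; that floor lies within the scatter) from compound 2 to compound 1 and an at least 1.7-fold higher number (0.23 log units; that floor lies within the scatter) from compound 3 to compound 4; the limit leaves it open whether they differ The results fit a change that carries over from one core to the other, but they do not prove it, since the true size of neither step is known and compounds at a limit cannot show that two steps match: the limit of > 100000 nM in this assay, at which 2 of the 4 values shown sit.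

The compounds shown leave open which part of the departing group matters, the selenium or the six-membered aromatic ring, as the change replaces both at once; a group that kept the ring but held sulfur in place of selenium would help to separate the two. Also open, going by these compounds, is what an amine, a carboxylic acid or a longer chain on this same carbon would give in this assay.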